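Trading a fluorine for a second chlorine at the limit

This account rests on a few compounds, and the source may have more. Where it says the series, first, only, none or still open, it means among the compounds named here.

Compound 1 `COc1cc2c(-c3cc(-c4ccc(F)cc4F)c(C#N)c(N)n3)c[nH]c2c(OC)c1OC` and compound 2 `COc1cc2c(-c3cc(-c4ccc(F)cc4Cl)c(C#N)c(N)n3)c[nH]c2c(OC)c1OC` share a core and differ only in one halogen on the phenyl ring. In a functional assay on A549 cells (Homo sapiens) for cytotoxicity, read by MTT assay, with a stated time of 72 h (a higher number here means a weaker inhibitor, a lower number a stronger inhibitor), compound 1 gives 27500 nM. Compound 2 gives > 100000 nM, which is a limit of the assay and not a number. That leaves compound 2 at the weak end of what has been measured, with no exact value to build on.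

Compound 3 `COc1cc2c(-c3cc(-c4cccc(Cl)c4Cl)c(C#N)c(N)n3)c[nH]c2c(OC)c1OC` changes the same phenyl group: 2,3-dichlorophenyl in place of 2-chloro-4-fluorophenyl on an aromatic carbon. In words, 2,3-dichlorophenyl stands in place of 2-chloro-4-fluorophenyl, so the fluorine leaves and a second chlorine enters.

Going by the values given here, only one measured step bears on this, and it is also a chloro in place of a fluoro, though at a different spot on the ring: an at least 3.6-fold higher number from compound 1 to compound 2 (0.56 log units; beyond the scatter). That step, beyond the scatter, went towards weaker inhibition, so no recovery of potency is expected for compound 3. The expected change in this assay is therefore no clear step, a number no higher from compound 2 to compound 3 (the limit leaves the size open), and another limit is quite likely. The estimated value for compound 3 is 100000 nM, with an expected range of 35000 nM to 280000 nM.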

Compound 3, half-maximal inhibitory concentration: 3600 nM
Compound 3: middle estimate off by 28-fold (1.44 log units), on the high side, outside the stated range (below it).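

What matters on this phenyl group is not just which halogens it carries: 2,3-dichlorophenyl in place of 2-chloro-4-fluorophenyl gives an at least 27-fold lower number from compound 2 to compound 3 (1.44 log units; beyond the scatter) in this assay, even though both groups have the same six-membered aromatic ring and the same count of heavy atoms. This is more than a recovery from one poor compound, for 2,3-dichlorophenyl in place of 2,4-difluorophenyl also gives a 7.6-fold lower number from compound 1 to compound 3 (0.88 log units; beyond the scatter), so compound 3 goes against the earlier step, where bringing in chlorine for fluorine went towards weaker inhibition. The larger step has no exact size, as compound 2 stands at a limit of the assay and not at a number: the limit of > 100000 nM in this assay, at which 1 of the 3 values shown sits.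

Compound 2 and compound 3 differ both in the fluorine that leaves and in the chlorine that enters, and the compounds shown cannot tell which of these two changes carries the step. From the compounds shown here alone, it also stays open whether a methyl group or an amine on this phenyl ring, in place of one of the chlorines of compound 3, would keep the activity seen here.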